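The source may report more compounds than this note shows. Statements on the series, on what has been measured and on what is new or still open speak of the compounds shown alone.

Measured compounds:
compound 1 `CCOC(=O)C1CCN(C(=O)CN2CN(c3ccccc3)C3(CCN(C(=O)c4ccc(C5CCCCC5)cc4)CC3)C2=O)CC1`, in an assay on HEK293 cells for displacement of a labelled ligand from NPC1-like intracellular cholesterol transporter 1 (Homo sapiens) (a lower number here means a stronger inhibitor, a higher number a weaker inhibitor), compound 1 gives 900 nM
compound 2 `CC(C)(C)OC(=O)NC1CCN(C(=O)CN2CN(c3ccccc3)C3(CCN(C(=O)c4ccc(C5CCCCC5)cc4)CC3)C2=O)CC1`, in this assay compound 2 gives 4800 nM

Within the data shown here, compound 1 holds the lower of the two numbers; the only step available, a 5.3-fold higher number from compound 1 to compound 2 (0.73 log units; beyond the scatter), is beyond the scatter. Compound 3 `CS(=O)(=O)N1CCN(C(=O)CN2CN(c3ccccc3)C3(CCN(C(=O)c4ccc(C5CCCCC5)cc4)CC3)C2=O)CC1` differs from compound 1 by 4-(methylsulfonyl)piperazin-1-yl in place of 4-(ethoxycarbonyl)piperidin-1-yl on a carbonyl carbon. That change touches the same place as the step from compound 1 to compound 2, where swapping the group on the saturated ring carbon cost potency, but it also exchanges the ring itself, so the bearing of that step is partial. A weakening of moderate size is therefore expected, a 2.4-fold higher number from compound 1 to compound 3 (0.39 log units; beyond the scatter). For compound 3 the estimate is 2200 nM, with a range from 700 nM to 7000 nM.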

Compound 3, half-maximal inhibitory concentration: 6300 nM
For compound 3 the middle estimate is 2.9-fold (0.46 log units) below the measured one; the range from low to high includes it.
By their numbers in this assay, from the lowest: compound 1; then compounds 2 and 3 (each within the scatter of the next).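

The step of a 7.0-fold higher number from compound 1 to compound 3 (0.85 log units; beyond the scatter) in this assay shows that a second replacement on this carbonyl carbon, one that also exchanges the ring, loses potency as well. Compound 1 keeps the lowest number, while compounds 2 and 3 lie within the scatter of each other. No measurement here explains the loss.

Compound 3 changes ring and substituent at once, so a 4-(ethoxycarbonyl)piperazin-1-yl group would be needed to tell the two apart. From the compounds shown here alone, how a free carboxylic acid or amine on the piperidine ring would read remains open.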